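Amino in place of chloro, tested on a second core

A few compounds are considered here, and "the series" means these few. Any claim that something is new, unique, unknown or untested is made for them only; others in the source may bear on it.

Measured so far:
compound 1 `ClCc1ccccc1Cn1cnc2c(Cl)nc(Cl)nc21` — 7070 nM
compound 2 `ClCc1cccc(Cn2cnc3c(Cl)nc(Cl)nc32)c1` — 20000 nM
compound 3 `Nc1nc(Cl)c2ncn(Cc3ccccc3CCl)c2n1` — a limit of the assay, > 100000 nM

In a functional assay on IGROV-1 cells (Homo sapiens) for cytotoxicity, read by sulforhodamine B assay, with a stated time of 48 h (on this read-out lower numbers stand for higher toxicity in this test and higher numbers for lower toxicity in this test), compound 2 shows the highest of the two numbers, with compound 1 the nearer one. The difference between the cores of compound 1 and compound 2 is not broken down here. From compound 1 to compound 3 the change is amino in place of chloro on an aromatic carbon, and it gave an at least 14-fold higher number from compound 1 to compound 3 (1.15 log units; beyond the scatter); compound 3 sits at the limit of > 100000 nM in this assay, at which 1 of the 3 values shown sits. Compound 4 `Nc1nc(Cl)c2ncn(Cc3cccc(CCl)c3)c2n1` is made from compound 2 by amino in place of chloro on an aromatic carbon, the same change at the same place. Since the step from compound 1 to compound 3 an at least 14-fold higher number from compound 1 to compound 3 (1.15 log units; beyond the scatter) was large, compound 4 is expected to show a step of a 7.5-fold higher number from compound 2 to compound 4 (0.88 log units; beyond the scatter) in this assay. Compound 4 is therefore estimated at 150000 nM, with a range expected from 60000 nM to 400000 nM, and a limit is likely.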

Compound 4, concentration lethal to 50% of the cells: 55000 nM
Beside the measured number, compound 4's estimate is 2.7-fold (0.44 log units) above it; measured number below the stated range.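

In this assay amino in place of chloro on an aromatic carbon gives a 2.8-fold higher number from compound 2 to compound 4 (0.44 log units; beyond the scatter), so the direction of the change is the same on both cores shown. Its size does not carry over from one core to the other: the same change on two cores in this assay, an at least 14-fold higher number (1.15 log units; beyond the scatter) from compound 1 to compound 3 and a 2.8-fold higher number (0.44 log units; beyond the scatter) from compound 2 to compound 4, at least 5.1-fold (0.71 log units) apart, beyond the scatter of two such steps. On these data alone, compound 3 stands at a limit of the assay, so the true size of the first step remains unknown, and two cores cannot show how the change would behave on a third: the limit of > 100000 nM in this assay, at which 1 of the 4 values shown sits.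

The compounds shown leave open whether a methylamino or a methoxy group on that aromatic carbon would behave as amino does. They also leave open whether either group would give a step of similar size on both cores.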